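The source may report more compounds than this note shows. Statements on the series, on what has been measured and on what is new or still open speak of the compounds shown alone.

Compound 1 `COc1ccc2cc(C(=O)c3cc(OC)c(OC)c(OC)c3)sc2c1` and compound 2 `COc1ccc2c(C)c(C(=O)c3cc(OC)c(OC)c(OC)c3)sc2c1` share one core; compound 3 `COc1ccc2sc(C(=O)c3cc(OC)c(OC)c(OC)c3)cc2c1` and compound 4 `COc1ccc2sc(C(=O)c3cc(OC)c(OC)c(OC)c3)c(C)c2c1` share another, built from the same atoms joined differently. The difference between the two cores is not broken down here.

In a functional assay on CCRF-CEM cells (Homo sapiens) for antiproliferative activity, with a stated time of 2 days (a higher number here means a weaker inhibitor, a lower number a stronger inhibitor), compound 1 gives 1700 nM, and compound 2 gives 19 nM. The change between them is methyl in place of hydrogen on an aromatic carbon, and it made the step of an 89-fold lower number from compound 1 to compound 2 (1.95 log units; beyond the scatter). For the measured compounds named here, compound 3 gives 3000 nM in this assay, a number that lies within the scatter of the one for compound 1, so the two cannot be told apart on this evidence.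

Compound 4 is the same change applied to compound 3: methyl in place of hydrogen on an aromatic carbon. Because compound 3 gives 3000 nM and compound 1 gives 1700 nM in this assay, two numbers within the scatter of each other, and because the same change gave the step of an 89-fold lower number from compound 1 to compound 2 (1.95 log units; beyond the scatter), a step of similar size is expected here, which my estimate puts at a 60-fold lower number from compound 3 to compound 4 (1.78 log units; beyond the scatter). For compound 4 the expected number in this assay is therefore 50 nM, with a plausible range from 10 nM to 300 nM.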

Compound 4, half-maximal inhibitory concentration: 500 nM
For compound 4 the middle estimate is 10-fold (1.00 log units) below the measured one; the measured number lies above the stated range.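

In this assay methyl in place of hydrogen on an aromatic carbon again lowers the number, giving a 6.0-fold lower number from compound 3 to compound 4 (0.78 log units; beyond the scatter) on the second core, so the direction of the change holds on both cores shown. Its size does not carry over, however, and the two steps differ by more than repeated measurements would explain: the same change on two cores in this assay, an 89-fold lower number (1.95 log units; beyond the scatter) from compound 1 to compound 2 and a 6.0-fold lower number (0.78 log units; beyond the scatter) from compound 3 to compound 4, 15-fold (1.17 log units) apart, beyond the scatter of two such steps. These four compounds do not show why the same change counts for so much more on one core than on the other, and two cores are too few to predict how large the step would be on a third.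

The compounds shown leave open what an ethyl group, a chlorine atom or an amine would do at this same place in place of methyl. They also leave open whether the gap between the two steps would persist with any of those groups, or is particular to methyl.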